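The source may hold more compounds than are shown below. What is called first, only, known or untested is meant among the compounds shown, and "the series" means these compounds.

Compound 1 `COc1cc2c(Oc3ccc(NC(=O)c4nnn(-c5ccccc5C)c4C)cc3F)ccnc2cc1OCCCN1CCCC1`; in a functional assay on HT-29 cells (Homo sapiens) for cytotoxicity, read by MTT assay, with a stated time of 72 h (on this read-out higher numbers stand for weaker inhibition and lower numbers for stronger inhibition), compound 1 gives 450 nM.
Compound 2 `COc1cc2c(Oc3ccc(NC(=O)c4nnn(-c5ccccc5)c4C)cc3F)ccnc2cc1OCCCN1CCCC1`; in this assay compound 2 gives 130 nM.
Compound 3 `COc1cc2c(Oc3ccc(NC(=O)c4nnn(-c5ccccc5C(F)(F)F)c4C)cc3F)ccnc2cc1OCCCN1CCCC1`; in this assay compound 3 gives 200 nM.

Compound 1 carries the highest number of the three: the steps of a 2.3-fold lower number from compound 1 to compound 3 (0.35 log units; beyond the scatter) and a 3.5-fold lower number from compound 1 to compound 2 (0.54 log units; beyond the scatter) both lie beyond the scatter, while a 1.5-fold higher number from compound 2 to compound 3 (0.19 log units; within the scatter) stays within it. Compound 4 `COc1cc2c(Oc3ccc(NC(=O)c4nnn(-c5ccccc5C)c4C)cc3F)ccnc2cc1OCCCN1CCCCC1` differs from compound 1 by piperidin-1-yl in place of pyrrolidin-1-yl on a saturated chain carbon, three bonds along the chain from an oxygen on an aromatic ring. Among the compounds with values here, none of the measured steps bears on this part of the molecule; all three concern a substituent on an aromatic carbon, so the data give no direct guide for the basic ring. No step beyond the scatter in this assay is therefore expected from compound 1 to compound 4. Compound 4 is estimated at 450 nM, with a range of 200 nM to 1000 nM, which would mean a step of no change at the digits printed from compound 1 to compound 4 (within the scatter).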

Compound 4, half-maximal inhibitory concentration: 450 nM
The estimate for compound 4 equals the measured number at the digits printed; low and high end bracket the measured number.
By their numbers in this assay, from the lowest: compounds 2 and 3 (each within the scatter of the next); then compounds 1 and 4 (each within the scatter of the next).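

In this assay, piperidin-1-yl in place of pyrrolidin-1-yl gives no change at the digits printed from compound 1 to compound 4 (within the scatter), the only step shown at this end of the molecule. With compound 1 as the starting point, a six-membered ring at the end of the chain therefore serves as well as a five-membered one, unlike the changes on the aromatic carbon, two of which went beyond the scatter. No evidence is available to explain this result. Still open, on these data alone, is whether the same change would read alike on compound 2 or compound 3, and how a morpholine ring, a dimethylamino group or a shorter chain would read here.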